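Aromatic substituent changes on the shared core against kinase 4

This account rests on a few compounds, and the source may have more. Where it says the series, first, only, none or still open, it means among the compounds named here.

Measured so far:
compound 1 `CN1C(=O)C(c2ccccc2)N(C)c2nc(Nc3ccc(S(N)(=O)=O)cc3)ncc21` — 383 nM
compound 2 `COc1cccc(C2C(=O)N(C)c3cnc(Nc4ccc(S(N)(=O)=O)cc4)nc3N2C)c1` — 954 nM
compound 3 `CN1C(=O)C(c2ccccc2F)N(C)c2nc(Nc3ccc(S(N)(=O)=O)cc3)ncc21` — 75 nM

In an assay on Sf9 cells for inhibition of serine/threonine-protein kinase 4 (Homo sapiens), read by luminescence and ADP-Glo, with a stated time of 1 h, in the presence of a further agent that is not named here (on this read-out lower numbers stand for stronger inhibition and higher numbers for weaker inhibition), compound 3 stands lowest of the three measured compounds: a 5.1-fold lower number from compound 1 to compound 3 (0.71 log units; beyond the scatter), and a 13-fold lower number from compound 2 to compound 3 (1.10 log units; beyond the scatter). Compound 4 `Cc1ccc(F)cc1C1C(=O)N(C)c2cnc(Nc3ccc(S(N)(=O)=O)cc3)nc2N1C` differs from compound 3 in one place: 5-fluoro-2-methylphenyl in place of 2-fluorophenyl on a saturated ring carbon. Among the measured compounds shown here, two measured steps bear on this. The gain of fluoro on an aromatic carbon was modest (a 5.1-fold lower number from compound 1 to compound 3 (0.71 log units; beyond the scatter)), while methoxy on an aromatic carbon went the other way (a 2.5-fold higher number from compound 1 to compound 2 (0.40 log units; beyond the scatter)). For the measured compounds named here, no measured step covers a methyl on this ring, nor the 5-fluoro-2-methyl pattern itself, so the outcome is uncertain. A small rise beyond the scatter is expected, a 1.7-fold higher number from compound 3 to compound 4 (0.24 log units; within the scatter). Compound 4 is therefore estimated at 130 nM, within 45 nM to 400 nM.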

Compound 4, half-maximal inhibitory concentration: 168 nM
Beside the measured number, compound 4's estimate is 1.3-fold (0.11 log units) below it; the measured number falls inside the stated range.
By their numbers in this assay, from the lowest: compound 3; then compound 4; then compound 1; then compound 2.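

In this assay the change to 5-fluoro-2-methylphenyl costs something against 2-fluorophenyl with a 2.2-fold higher number from compound 3 to compound 4 (0.35 log units; beyond the scatter) yet still gains over phenyl with a 2.3-fold lower number from compound 1 to compound 4 (0.36 log units; beyond the scatter) and over 3-methoxyphenyl with a 5.7-fold lower number from compound 2 to compound 4 (0.75 log units; beyond the scatter) at this saturated ring carbon. A ring carrying both a methyl and a fluoro thus keeps part of the gain seen with fluoro alone, while compound 3 stays lowest of the four. No evidence at hand accounts for these shifts.

Open, from the compounds shown here alone, is what a methyl alone on this ring would give, and whether chloro or trifluoromethyl would match fluoro. Also open, going by these compounds, is how a ring bearing an amine or a carboxylic acid would fare here.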